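This account rests on a few compounds, and the source may have more. Where it says the series, first, only, none or still open, it means among the compounds named here.

Measured compounds:

- compound 1, `COc1cc(-c2nc(C(c3ccc(F)cc3)c3ccc(F)cc3)sc2CC(=O)O)ccn1`: 60%
- compound 2, `O=C(O)Cc1sc(C(c2ccccc2)c2ccccc2)nc1-c1ccccc1`: 80%

In an in vitro functional assay on HEK285-7 cells for antagonist activity at prostaglandin D2 receptor 2 (Homo sapiens), read by BRET and beta-arrestin recruitment (a lower number here means a smaller maximal response, a higher number a larger maximal response), compound 1 gives 60% and stands lowest of the two numbers in hand. Its nearest neighbour is compound 2, which in this assay gives 80%, a higher number, and the gap between the two is beyond the usual scatter. For the measured compounds named here, no step between these two compounds is computed, since they differ in more than one place, so their two values are all that can be said of them.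

Compound 3, `O=C(O)Cc1sc(C(c2ccc(F)cc2)c2ccc(F)cc2)nc1-c1ccnc(O)c1`, is the next compound to be measured. It differs from compound 1 in one place: hydrogen in place of methyl on an oxygen on an aromatic ring. Cut one bond further out, the change reads methoxy to hydroxy, or 2-methoxypyridin-4-yl to 2-hydroxypyridin-4-yl. Going by the values given here, no measured pair shows such a change, so nothing in the data tells the direction of the step in this assay. The expectation is a step from compound 1 to compound 3 of no change at the digits printed from compound 1 to compound 3 (within the scatter), that is, none beyond the scatter. Compound 3 is thus estimated at 60% in this assay, with a range from 45% to 78%.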

Compound 3, largest response reached (reported as efficacy), in percent of the reference or control that the assay uses: 60%
Beside the measured number, compound 3's estimate shows no gap at the digits printed; low and high end bracket the measured number.
By their numbers in this assay, from the lowest: compounds 1 and 3 (each within the scatter of the next); then compound 2.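

In this assay, the series now has its first single-place change, hydrogen in place of methyl on an oxygen on an aromatic ring, and it reads no change at the digits printed from compound 1 to compound 3 (within the scatter). For the compounds shown here, the earlier compounds offered no such step, so this is the first direct reading at this position: the methyl, with its one carbon, can leave without the maximal response moving beyond the scatter, and 2-methoxypyridin-4-yl and 2-hydroxypyridin-4-yl cannot be told apart in this read-out. No measurement in hand bears on why the number holds across methoxy to hydroxy.

Still open, from the compounds shown here alone, is how far this tolerance extends at the same position: a longer chain on the oxygen, such as ethyl or propyl, or an amine or a chlorine in place of the methoxy, could leave the number where it stands or shift it in either direction. Going by these compounds, the reading also rests on a single pair, so whether the same change gives the same result with other groups elsewhere on the shared core remains unknown.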